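Methylamino in Place of Chloro on a Substance-P Receptor Binder

A few compounds are considered here, and "the series" means these few. Any claim that something is new, unique, unknown or untested is made for them only; others in the source may bear on it.

Compound 1, `O=C(NCc1cc(C(F)(F)F)cc(C(F)(F)F)c1)c1c(CCl)nc2ccccc2c1-c1ccccc1`, gives 26 nM in an in vitro assay on UC11MG cells for binding affinity to Substance-P receptor (Homo sapiens), read by radioligand binding; on this read-out higher numbers stand for weaker inhibition and lower numbers for stronger inhibition.
Compound 2, `COCc1nc2ccccc2c(-c2ccccc2)c1C(=O)N(C)Cc1cc(C(F)(F)F)cc(C(F)(F)F)c1`, gives 11 nM in this assay.

Among the two measured compounds, compound 1 stands at the higher number in this assay, which means the weaker binding of the pair. Compound 2 gives the lower number, and the gap between the two lies beyond the usual scatter of repeated measurements. Compound 2 differs from compound 1 in more than one place, so the two values cannot be read as a single structural step.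

The compound not yet measured is compound 3, `CNCc1nc2ccccc2c(-c2ccccc2)c1C(=O)NCc1cc(C(F)(F)F)cc(C(F)(F)F)c1`. It differs from compound 1 in exactly one place: methylamino in place of chloro on a saturated chain carbon bound to an aromatic carbon. For the measured compounds named here, no measured pair shows this particular change, so the expectation rests only on compound 1 itself and on the fact that a near relative, compound 2, reaches a lower number. A step of modest size toward a lower number, not far beyond the scatter, is expected: a 1.7-fold lower number from compound 1 to compound 3 (0.24 log units; within the scatter). For compound 3 in this assay the estimated value is 15 nM, with a range from 4 nM to 60 nM.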

Compound 3, half-maximal inhibitory concentration: 0.011 nM
Estimate against measurement, compound 3: 1400-fold (3.13 log units) above, and the stated range ends above it.
By their numbers in this assay, from the lowest: compound 3; then compound 2; then compound 1.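

In this assay, putting (methylamino)methyl in place of chloromethyl gives a 2400-fold lower number from compound 1 to compound 3 (3.37 log units; beyond the scatter), so a single change on a saturated chain carbon bound to an aromatic carbon can move the number by a very large amount. The earlier compounds shown here could not show this, since they differ from each other in more than one place and offered no single step to read. Here only one group changes: chloro, with no hydrogen-bond donor or acceptor, leaves, and methylamino, with one of each, enters, yet nothing shown explains why the step is so large.

Going by these compounds, it remains open whether a plain amino group, a dimethylamino group or a hydroxyl group at this place would also reach so low a number, which would help separate the part played by the nitrogen, its hydrogen and its methyl. On these data alone, it is also open whether methylamino would give a step of this size on the core of compound 2, which carries a different amide.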